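A few compounds are considered here, and "the series" means these few. Any claim that something is new, unique, unknown or untested is made for them only; others in the source may bear on it.

Two compounds of the series stand measured in a functional assay on BV-2 cells (Mus musculus) for inhibition, read by Griess assay, with a stated time of 24 h; a lower number here means a stronger inhibitor, a higher number a weaker inhibitor. Compound 1, `COc1cc(CC[C@H]2C[C@H](O)C[C@@H](c3ccc(O)c(OC)c3)O2)ccc1O`, gives 45900 nM in this assay. Compound 2, `Oc1ccc(CC[C@H]2C[C@@H](O)C[C@@H](c3ccc(O)cc3)O2)cc1`, gives 39700 nM in this assay, the lower of the two numbers, though the gap to compound 1 lies within the scatter. Compound 3, `Oc1ccc(CC[C@H]2C[C@H](O)C[C@@H](c3ccc(O)cc3)O2)cc1`, awaits measurement. Its difference from compound 2: the two compounds have the same atoms and bonds and differ only in configuration as drawn: 1 of 3 stereo elements differ; a stereocentre at a saturated ring carbon is drawn R in compound 2 and S in compound 3. Nothing measured yet speaks to such a change, so no step beyond the scatter is expected. Compound 3 is estimated at 42000 nM in this assay, between 20000 nM and 90000 nM, a step of a 1.1-fold higher number from compound 2 to compound 3 (0.02 log units; within the scatter) as expected.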

Compound 3, half-maximal inhibitory concentration: 38100 nM
Beside the measured number, compound 3's estimate is 1.1-fold (0.04 log units) above it; low and high end bracket the measured number.
By their numbers in this assay, from the lowest: compounds 3, 2 and 1 (each within the scatter of the next).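

In this assay, among the compounds shown here, turning the stereocentre at a saturated ring carbon from R to S gives a 1.0-fold lower number from compound 2 to compound 3 (0.02 log units; within the scatter), the first step that can be read. At these numbers, this configuration makes no difference beyond the scatter. The step speaks to that one centre alone: the fact that compounds 2 and 3 differ only in the configuration as drawn.

Still open, as far as these compounds go, is whether the other two stereo elements would behave the same way. Also open, from the compounds shown here alone, is whether an amine or a carboxylic acid in place of a hydroxyl group on the shared core would move the number beyond the scatter.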